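The source may hold more compounds than are shown below. What is called first, only, known or untested is meant among the compounds shown, and "the series" means these compounds.

Three compounds of the series have been examined so far. Compound 1 `O=c1c2cnn(-c3ccc(F)cc3)c2ncn1CC1(O)CCN(Cc2ccccc2)CC1` carries an unsubstituted benzyl group on the piperidine nitrogen, and in an assay on Sf21 cells for inhibition of ubiquitin carboxyl-terminal hydrolase 7 (Homo sapiens), read by spectrophotometry, with stated times of 30 min and 2 h (on this read-out higher numbers stand for weaker inhibition and lower numbers for stronger inhibition), compound 1 gives "not determined" (no result reported). Compound 2 `O=c1c2cnn(-c3ccc(F)cc3)c2ncn1CC1(O)CCN(Cc2ccc(Cl)cc2)CC1` carries the 4-chlorobenzyl group, and in this assay compound 2 gives 8000 nM. Compound 3 `O=c1c2cnn(-c3ccc(F)cc3)c2ncn1CC1(O)CCN(Cc2ccccc2Br)CC1` carries the 2-bromobenzyl group, and in this assay compound 3 gives 3100 nM. For the measured compounds named here, the one step that can be read between measured compounds is a 2.6-fold lower number from compound 2 to compound 3 (0.41 log units; beyond the scatter). On the numbers available, compound 3 stands lowest of the two reported values, the nearest being compound 2.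

Compound 4 `O=c1c2cnn(-c3ccc(F)cc3)c2ncn1CC1(O)CCN(Cc2ccc(Br)cc2)CC1` is the next candidate. The change from compound 3 is 4-bromophenyl in place of 2-bromophenyl on a saturated chain carbon bound to an amine nitrogen in a ring. Going by the values given here, the only measured step that bears on it is the step from compound 2 to compound 3, which exchanged both halogen and position at once, so the position component cannot be separated from the halogen component. Moving the bromine back to the same position held by the chlorine in compound 2 is therefore expected to give a modest rise in the number, toward the value of compound 2 8000 nM, with the estimated step being a 1.8-fold higher number from compound 3 to compound 4 (0.25 log units; within the scatter). For compound 4 in this assay the expected value is 5500 nM, within a range from 2500 nM to 14000 nM.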

Compound 4, half-maximal inhibitory concentration: 6700 nM
Beside the measured number, compound 4's estimate is 1.2-fold (0.09 log units) below it; measured number inside the range.
By their numbers in this assay, from the lowest: compound 3; then compounds 4 and 2 (each within the scatter of the next).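

Moving the bromine alone, with 4-bromophenyl in place of 2-bromophenyl on a saturated chain carbon bound to an amine nitrogen in a ring, gives in this assay a 2.2-fold higher number from compound 3 to compound 4 (0.33 log units; beyond the scatter) and so shows that the place of the halogen on this benzyl group registers in the read-out on its own. Exchanging the halogen alone, with bromo in place of chloro on an aromatic carbon, gives a 1.2-fold lower number from compound 2 to compound 4 (0.08 log units; within the scatter) and so does not separate chloro from bromo; among these compounds, the gap between the 2-bromobenzyl and 4-chlorobenzyl groups therefore follows the place of the halogen rather than its identity. No measurement on these compounds gives a reason for the preference of 2-bromophenyl over 4-bromophenyl.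

For the compounds shown here, compound 1 has no reported result, so no step from the unsubstituted benzyl group can be read, and whether either halogen improves on hydrogen remains unknown. Also open, from the compounds shown here alone, is whether the preference holds for other groups at the place of the bromine in compound 3, such as chloro, methoxy or a carboxylic acid.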